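A piperidine in place of the sulfone on the side chain

The source may hold more compounds than are shown below. What is called first, only, known or untested is meant among the compounds shown, and "the series" means these compounds.

Among the measured compounds shown here, compound 2, `CS(=O)(=O)CCn1c(=N)sc2cc(OC(F)(F)F)ccc21`, is the single compound with a number in a functional assay on the whole organism with Rattus norvegicus as the target; on this read-out lower numbers stand for an effect already at smaller amounts and higher numbers for an effect only at larger amounts of compound: compound 2 gives 1.8 mg/kg. Compound 1, `COC(=O)Cn1c(=N)sc2cc(OC(F)(F)F)ccc21`, shows in this assay only a limit, > 10 mg/kg. For the measured compounds named here, the one measured step, an at least 5.5-fold lower number from compound 1 to compound 2 (0.74 log units; beyond the scatter), concerns methoxycarbonyl against (methylsulfonyl)methyl and has no counterpart among the other compounds. Compound 3, `N=c1sc2cc(OC(F)(F)F)ccc2n1CCN1CCCCC1`, differs from compound 2 by piperidin-1-yl in place of methylsulfonyl on a saturated chain carbon, two bonds along the chain from an aromatic nitrogen. Going by the values given here, no measured step exchanges methylsulfonyl for piperidin-1-yl, so the step from compound 2 to compound 3 in this assay rests on no comparable precedent, and the size and direction remain open. The change in compound 3 is therefore expected to give no step beyond the scatter, a 1.7-fold higher number from compound 2 to compound 3 (0.22 log units; within the scatter), with wide uncertainty. Compound 3 is estimated at 3 mg/kg in this assay, in a range from 0.8 mg/kg to 12 mg/kg.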

Compound 3, dose for half-maximal effect: 2 mg/kg
For compound 3 the middle estimate is 1.5-fold (0.18 log units) above the measured one, within the range that was stated.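

In this assay, exchanging methylsulfonyl for piperidin-1-yl at this place on the side chain gives a 1.1-fold higher number from compound 2 to compound 3 (0.05 log units; within the scatter), so two very different end groups, one of them a six-membered non-aromatic ring, cannot be told apart on this read-out. Both now stand apart from the methoxycarbonyl side chain, with an at least 5.0-fold lower number from compound 1 to compound 3 (0.69 log units; beyond the scatter). Compound 1 has only a limit here and not a number, so the true size of that step stays unknown: the limit of > 10 mg/kg in this assay, at which 1 of the 3 values shown sits.

On these data alone, whether a morpholine, an open-chain amine such as dimethylamino or a carboxylic acid would fit this place equally well remains open. So does the effect of a longer chain between the aromatic nitrogen and the end group, and the compounds shown do not tell what the sulfone and the piperidine have in common.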